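One Side-Chain Change Carried onto a Smaller Core

This account rests on a few compounds, and the source may have more. Where it says the series, first, only, none or still open, it means among the compounds named here.

Compound 2, `CC1=CCC[C@H]2[C@](C)(CC3=CC(=O)C=C(N[C@@H](C)C(=O)O)C3=O)[C@@H](C)CC[C@]12C`, was tested in a functional assay on HeLa cells (Homo sapiens) for cytotoxicity, read by MTT assay, with a stated time of 72 h (a higher number here means a weaker inhibitor, a lower number a stronger inhibitor), where compound 2 gives 11700 nM. Compound 1, `CSCC[C@H](NC1=CC(=O)C=C(C[C@]2(C)[C@@H](C)CC[C@]3(C)C(C)=CCC[C@@H]23)C1=O)C(=O)O`, differs from it in one place: (methylsulfanyl)methyl in place of hydrogen on a saturated chain carbon, two bonds along the chain from an amine nitrogen and a carbonyl carbon. In this assay compound 1 gives 13900 nM, so the step is a 1.2-fold higher number from compound 2 to compound 1 (0.07 log units; within the scatter). Compound 3, `C[C@H](NC1=CC(=O)C=C(C(C)(C)C)C1=O)C(=O)O`, is built on a different core; how the two cores differ is not broken down here. In this assay compound 3 gives 89100 nM, the highest number among the three measured compounds. Compound 4, `CSCC[C@H](NC1=CC(=O)C=C(C(C)(C)C)C1=O)C(=O)O`, stands to compound 3 as compound 1 stands to compound 2: (methylsulfanyl)methyl in place of hydrogen on a saturated chain carbon, two bonds along the chain from an amine nitrogen and a carbonyl carbon. The place of the change is described in the same words in both pairs, so this is the same change. Because the earlier step of a 1.2-fold higher number from compound 2 to compound 1 (0.07 log units; within the scatter) stayed within the scatter, the new step is expected to be small as well, about a 1.1-fold higher number from compound 3 to compound 4 (0.05 log units; within the scatter). Compound 4 is therefore estimated at 100000 nM, with a likely range from 40000 nM to 250000 nM.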

Compound 4, half-maximal inhibitory concentration: 77400 nM
Estimate against measurement, compound 4: 1.3-fold (0.11 log units) above, within the range that was stated.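

In this assay, placing (methylsulfanyl)methyl on the core of compound 3 gives a 1.2-fold lower number from compound 3 to compound 4 (0.06 log units; within the scatter), a step too small to tell apart from the ordinary variation between repeated measurements. Set beside the step on the core of compound 2, the result is consistent across the two cores, as far as this assay can show: the same change on two cores in this assay, a 1.2-fold higher number (0.07 log units; within the scatter) from compound 2 to compound 1 and a 1.2-fold lower number (0.06 log units; within the scatter) from compound 3 to compound 4, 1.4-fold (0.14 log units) apart, within the scatter of two such steps. This shows that the change left the number essentially unmoved on both cores, but with so little movement there is no clear effect to carry across, and two cores cannot show how the change would behave on a third.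

The compounds shown leave open whether another group on the same saturated chain carbon, such as a hydroxyl group, a phenyl ring or a longer chain, would move the number beyond the scatter on either core. They also leave open whether this change would stay as small in any other test.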